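Matched methoxyphenyl switch on two different triazole chalcone cores

The compounds below may be only part of what the source reports. "The series", "measured", "known", "first", "only" and "open" are said of these compounds alone.

Of the compounds shown here, three from this series have been measured in a functional assay on SK-N-SH cells (Homo sapiens) for inhibition, read by MTT assay; a higher number here means a weaker inhibitor, a lower number a stronger inhibitor. Compound 1 `COc1ccccc1N1CCN(CC(=O)Nc2ccc(C(=O)/C=C/c3cn(Cc4ccc(Br)cc4)nn3)cc2)CC1` gives 28000 nM. Compound 2 `CCCCCCCCn1cc(/C=C/C(=O)c2ccc(NC(=O)CN3CCN(c4ccc([N+](=O)[O-])cc4)CC3)cc2)nn1` gives 51400 nM. Compound 3 `O=C(CN1CCN(c2ccc([N+](=O)[O-])cc2)CC1)Nc1ccc(C(=O)/C=C/c2cn(Cc3ccc(Br)cc3)nn2)cc1` gives 26500 nM. All three numbers sit within the usual scatter of one another, so none of them can be called the stronger or the weaker inhibitor.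

Compound 3 and compound 1 differ in one place: 2-methoxyphenyl in place of 4-nitrophenyl on an amine nitrogen in a ring. This change produced a 1.1-fold higher number from compound 3 to compound 1 (0.02 log units; within the scatter).

Compound 2 and compound 3 differ elsewhere, in their cores: heptyl in place of 4-bromophenyl on a saturated chain carbon bound to an aromatic nitrogen. This difference produced a 1.9-fold lower number from compound 2 to compound 3 (0.29 log units; within the scatter).

Compound 4 `CCCCCCCCn1cc(/C=C/C(=O)c2ccc(NC(=O)CN3CCN(c4ccccc4OC)CC3)cc2)nn1` has not yet been measured. It stands to compound 2 as compound 1 stands to compound 3: 2-methoxyphenyl in place of 4-nitrophenyl on an amine nitrogen in a ring. The surroundings of the change are described identically for both pairs, so it is the same change, made on the core of compound 2 rather than on that of compound 3.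

Because the same change gave a 1.1-fold higher number from compound 3 to compound 1 (0.02 log units; within the scatter) on the core of compound 3, the step from compound 2 to compound 4 is expected to be of similar size, a 1.1-fold higher number from compound 2 to compound 4 (0.03 log units; within the scatter), which means a number for compound 4 that stays within the scatter of compound 2. On this basis compound 4 is estimated to give 55000 nM in this assay, with an expected range from 25000 nM to 120000 nM. The expectation rests on a single measured pair, so it carries little more certainty than the scatter itself.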

Compound 4, half-maximal inhibitory concentration: 21500 nM
Compound 4: middle estimate off by 2.6-fold (0.41 log units), on the high side; the whole stated range lies above it.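

In this assay, among these compounds, 2-methoxyphenyl in place of 4-nitrophenyl gave a 2.4-fold lower number from compound 2 to compound 4 (0.38 log units; beyond the scatter) on the core of compound 2, whereas the same change had stayed within the scatter on the core of compound 3, yet the two steps are not told apart: the same change on two cores in this assay, a 1.1-fold higher number (0.02 log units; within the scatter) from compound 3 to compound 1 and a 2.4-fold lower number (0.38 log units; beyond the scatter) from compound 2 to compound 4, 2.5-fold (0.40 log units) apart, within the scatter of two such steps Read the other way, heptyl in place of 4-bromophenyl gave a 1.3-fold lower number from compound 1 to compound 4 (0.11 log units; within the scatter), and this step likewise cannot be told apart from its counterpart on the 4-nitrophenyl compounds: the same change on two cores in this assay, a 1.9-fold lower number (0.29 log units; within the scatter) from compound 2 to compound 3 and a 1.3-fold higher number (0.11 log units; within the scatter) from compound 4 to compound 1, 2.5-fold (0.40 log units) apart, within the scatter of two such steps The two pairs are therefore compatible with the change carrying from one core to the other, but they do not show that it acts alike on both cores, and with only two pairs they say nothing about any other core.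

The compounds shown leave open whether the step on the core of compound 2 follows from the loss of 4-nitrophenyl or from the arrival of 2-methoxyphenyl, which a plain phenyl group at the same place could help to separate. They also leave open whether the step seen with heptyl would recur with a shorter chain in its place.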